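Swapping an Aromatic Ester Tail for a Cyclohexyl Chain

This account rests on a few compounds, and the source may have more. Where it says the series, first, only, none or still open, it means among the compounds named here.

Compound 1 `C/C=C1/[C@H](O[C@@H]2O[C@H](CO)[C@@H](O)[C@H](O)[C@H]2O)OC=C(C(=O)OC)[C@H]1CC(=O)O`: > 15000 nM
Compound 2 `C/C=C1/[C@H](O[C@@H]2O[C@H](CO)[C@@H](O)[C@H](O)[C@H]2O)OC=C(C(=O)OC)[C@H]1CC(=O)OCCc1ccc(OC)c(OC)c1`: > 15000 nM

In a functional assay on SK-BR-3 cells (Homo sapiens) for antiproliferative activity, read by MTT assay, with a stated time of 72 h (a higher number here means a weaker inhibitor, a lower number a stronger inhibitor), compound 1 gives > 15000 nM, a limit of the assay. Compound 2 gives > 15000 nM in this assay, also a limit. Hence a step that the two limits leave unreadable from compound 1 to compound 2 cannot be read, and compound 2 stands only at the limit of > 15000 nM in this assay, at which 2 of the 2 values shown sit. Compound 3 `C/C=C1/[C@H](O[C@@H]2O[C@H](CO)[C@@H](O)[C@H](O)[C@H]2O)OC=C(C(=O)OC)[C@H]1CC(=O)OCCC1CCCCC1` differs from compound 2 by cyclohexyl in place of 3,4-dimethoxyphenyl on a saturated chain carbon, two bonds along the chain from an oxygen next to a carbonyl group. Among the compounds with values here, no measured step bears on this change. Compound 3 is therefore expected to remain at the limit, with an estimate of 20000 nM ranging from 8000 nM to 60000 nM. The expected step that the limit leaves unreadable from compound 2 to compound 3 is none beyond the scatter.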

Compound 3, half-maximal inhibitory concentration: 2000 nM
The estimate for compound 3 lay 10-fold (1.00 log units) above the measured number, and the stated range ends above it.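

In this assay this position now gives a readable result: cyclohexyl in place of 3,4-dimethoxyphenyl gives an at least 7.5-fold lower number from compound 2 to compound 3 (0.87 log units; beyond the scatter) and so the ring at the end of the chain decides the outcome here. The 2-cyclohexylethyl group in place of hydrogen gives an at least 7.5-fold lower number from compound 1 to compound 3 (0.87 log units; beyond the scatter) while compound 2 shows that an ester alone does not produce this. Only compound 3 leaves the limit shared by the other compounds: the limit of > 15000 nM in this assay, at which 2 of the 3 values shown sit.

As far as these compounds go, whether the step comes from losing aromaticity or losing the methoxy groups stays open. An unsubstituted phenyl, a cyclopentyl or a longer chain could separate these.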